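This account rests on a few compounds, and the source may have more. Where it says the series, first, only, none or still open, it means among the compounds named here.

The series shares a furan-hydrazone core. Compound 1, with structure `COc1ccccc1/C=N/NC(=O)c1ccc(-c2ccc(F)cc2F)o1`, carries a methoxy on the benzoyl ring. In a functional assay on KB cells (Homo sapiens) for antiproliferative activity, read by sulforhodamine B assay, with a stated time of 48 h (a higher number here means a weaker inhibitor, a lower number a stronger inhibitor), compound 1 reaches only the assay limit, > 40000 nM, which is a limit rather than a number. Compound 2, with structure `O=C(N/N=C/c1ccc(-c2ccc(F)cc2F)o1)c1ccccc1O`, bears a hydroxyl on that ring instead. In this assay compound 2 gives 55300 nM, the only number within the pair shown. The other value in this assay is a limit, as recorded by the limit of > 40000 nM in this assay, at which 1 of the 2 values shown sits. Compound 2 thus stands as the single measured point among the values at hand.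

Compound 3, with structure `O=C(N/N=C/c1ccc(-c2ccc(F)cc2)o1)c1ccccc1O`, differs from compound 2 only in the change (hydrogen in place of fluoro on an aromatic carbon), that is, from 2,4-difluorophenyl to 4-fluorophenyl. For the measured compounds named here, no measured step between two compounds is available to calibrate such a change. The step from compound 2 to compound 3 in this assay is therefore expected to be small, a 1.0-fold lower number from compound 2 to compound 3 (0.00 log units; within the scatter), with no direction beyond the usual scatter. For compound 3 the estimate in this assay is 55000 nM, within a range from 20000 nM to 150000 nM.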

Compound 3, half-maximal inhibitory concentration: 39000 nM
Beside the measured number, compound 3's estimate is 1.4-fold (0.15 log units) above it, and the stated range covers the measured number.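

The pair gives the series its first readable step: with hydrogen in place of fluoro on an aromatic carbon, ortho to a large group and meta to a fluoro group, this assay shows a 1.4-fold lower number from compound 2 to compound 3 (0.15 log units; within the scatter). At this position, then, the change from 2,4-difluorophenyl to 4-fluorophenyl gives no difference that this read-out can separate from the scatter, and compound 2 and compound 3 stand level. The one value in the set that is a limit and not a number belongs to compound 1, so it adds no further step here: the limit of > 40000 nM in this assay, at which 1 of the 3 values shown sits.

The compounds shown leave open whether any group at this position can move the number beyond the scatter, as only fluoro and hydrogen appear there, and a chloro, a trifluoromethyl or an amine on the same carbon would put that to the test. They also leave open what the remaining fluoro group of the 4-fluorophenyl ring contributes, and whether the same change would read alike with a group other than hydroxyl on the benzoyl ring.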